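Replacing a Methylphenyl Amide with a Hydroxyphenyl Amide

The source may hold more compounds than are shown below. What is called first, only, known or untested is meant among the compounds shown, and "the series" means these compounds.

Measured so far in a functional assay on the whole organism for inhibition, with Rattus norvegicus as the target, read by paw edema, with stated times of 30 min and 3 h, at a dose of 0.28 mmol/kg by the oral route; a lower number here means less inhibition, a higher number more inhibition at the dose given (going by the name of the read-out):
compound 1 `CCNC(=O)c1nc(-c2cc(OC)c(OC)c(OC)c2)n(-c2ccc(OC)cc2)n1` gives 69%
compound 2 `COc1ccc(-n2nc(C(=O)Nc3ccc(C)cc3)nc2-c2cc(OC)c(OC)c(OC)c2)cc1` gives 60%
compound 3 `COc1ccc(-n2nc(C(=O)Nc3ccccc3C)nc2-c2cc(OC)c(OC)c(OC)c2)cc1` gives 50%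

Compound 3 holds the lowest of the three numbers in this assay. The step of a number 19 percentage points lower from compound 1 to compound 3 (beyond the scatter) lies beyond the scatter, but the step of a number 10 percentage points lower from compound 2 to compound 3 (within the scatter) lies within it, so the number for compound 3 is clearly lower only than that of compound 1. Compound 4 `COc1ccc(-n2nc(C(=O)Nc3ccc(O)cc3)nc2-c2cc(OC)c(OC)c(OC)c2)cc1` differs from compound 3 by 4-hydroxyphenyl in place of 2-methylphenyl on an amide-type nitrogen. Within the data shown here, no measured step swaps in a 4-hydroxyphenyl. The nearest pointers are the other amide changes, and a number 9 percentage points lower from compound 1 to compound 2 (within the scatter) as well as a number 10 percentage points lower from compound 2 to compound 3 (within the scatter) stayed within the scatter. Another 4-substituted phenyl on this nitrogen, compound 2, gives 60%. A step of a number 7 percentage points higher from compound 3 to compound 4 (within the scatter) is therefore expected, not beyond the scatter. Compound 4 is estimated at 57%, in a range from 40% to 74%.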

Compound 4, a percentage reported as inhibition, in the whole organism at one dose (the size of the read-out at that dose, not a potency): 50%
The estimate for compound 4 lay 7 percentage points above the measured number; the measured number falls inside the stated range.
By their numbers in this assay, from the lowest: compounds 3, 4, 2 and 1 (each within the scatter of the next, the first and the last beyond it).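

In this assay, 4-hydroxyphenyl in place of 2-methylphenyl gives no change at the digits printed from compound 3 to compound 4 (within the scatter), and hydroxy in place of methyl on the aromatic carbon gives a number 10 percentage points lower from compound 2 to compound 4 (within the scatter), so neither change on this phenyl ring moves the number beyond the scatter. Replacing ethyl on the amide-type nitrogen with 4-hydroxyphenyl gives a number 19 percentage points lower from compound 1 to compound 4 (beyond the scatter), a step beyond the scatter, as the 2-methylphenyl group also gave. Nothing available explains these numbers.

Going by these compounds, whether an amine or a carboxylic acid on the phenyl ring would give a different number remains open. So does the effect of a propyl chain in place of ethyl.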